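Methyl in place of cyclohexyl on the ring nitrogen

A few compounds are considered here, and "the series" means these few. Any claim that something is new, unique, unknown or untested is made for them only; others in the source may bear on it.

Measured compounds:
compound 1 `Cc1cc(/C=C2\S/C(=N\c3ccccc3)N(C3CCCCC3)C2=O)c(C)n1-c1ccccc1` — > 200000 nM
compound 2 `Cc1cc(/C=C2\S/C(=N\c3ccccc3)N(C3CCCCC3)C2=O)c(C)n1-c1cccc(C(F)(F)F)c1` — > 170000 nM
compound 3 `Cc1cc(/C=C2\S/C(=N\c3ccccc3)N(C3CCCCC3)C2=O)c(C)[nH]1` — 23000 nM

In an ADME assay on L6 cells (Rattus norvegicus) for cytotoxicity, read by microscopy and resazurin assay, with a stated time of 72 h (a higher number here means that more compound is needed for the effect, a lower number that less compound is needed), compound 1 gives > 200000 nM, which is a limit of the assay and not a number. Compound 2 likewise gives only a limit, > 170000 nM. Compound 3 gives a number, 23000 nM. The measured steps all concern the aromatic nitrogen: a step that the two limits leave unreadable from compound 1 to compound 2, an at least 8.6-fold lower number from compound 1 to compound 3 (0.93 log units; beyond the scatter) and an at least 7.3-fold lower number from compound 2 to compound 3 (0.86 log units; beyond the scatter).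

Compound 4 `Cc1cc(/C=C2\S/C(=N\c3ccccc3)N(C)C2=O)c(C)n1-c1ccccc1` differs from compound 1 elsewhere: methyl in place of cyclohexyl on an amide-type nitrogen in a ring. Among the compounds with values here, the amide-type nitrogen in the ring carries cyclohexyl in all three measured compounds, so no measured step bears on this change, and the scatter-free evidence for its size is absent. Compound 1 sits at a limit in this assay , and with nothing pointing the other way, the step of a number no higher from compound 1 to compound 4 (the limit leaves the size open) is expected to stay within the scatter. Compound 4 is therefore estimated at 200000 nM, with a range of 60000 nM to 500000 nM, most likely again reported only as a limit.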

Compound 4, half-maximal effective concentration: > 230000 nM
Compound 4 was reported as a limit (the forecaster's own chance of this, stated with the estimate: 70%); at least 1.1-fold (0.06 log units) between middle value and limit.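

Compound 4 gives > 230000 nM, which is a limit and not a number. Compound 1 gives > 200000 nM, also a limit, so the step between compound 1 and compound 4 cannot be read. The compounds shown leave open whether methyl in place of cyclohexyl on the amide-type nitrogen in the ring changes the read-out at all.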